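Replacing methoxy with fluoro in compound 3

This account rests on a few compounds, and the source may have more. Where it says the series, first, only, none or still open, it means among the compounds named here.

Compound 1 `COc1ccc(S(=O)(=O)Oc2ccccc2/C=C(\C#N)C(=O)Nc2nnc(-c3cccs3)s2)cc1` gives 76%
Compound 2 `COc1ccc(S(=O)(=O)Oc2ccccc2/C=C(\C#N)C(=O)Nc2nnc(Cc3cccc4ccccc34)s2)cc1` gives 78%
Compound 3 `COc1ccc(S(=O)(=O)Oc2ccccc2/C=C(\C#N)C(=O)Nc2nnc(Cc3ccc(F)cc3)s2)cc1` gives 76%

The three compounds were tested in a functional assay on RS4-11 cells (Homo sapiens) for inhibition, read by CCK-8 assay, with a stated time of 48 h, tested at 20 uM (a lower number here means less inhibition of growth, a higher number more inhibition of growth at the concentration tested), and they lie within the scatter of one another. On these numbers, compound 3, at 76%, cannot be told apart from the other two.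

Compound 4 `N#C/C(=C\c1ccccc1OS(=O)(=O)c1ccc(F)cc1)C(=O)Nc1nnc(Cc2ccc(F)cc2)s1` is compound 3 with fluoro in place of methoxy on an aromatic carbon, para to a large group (fluoro in place of methoxy on an aromatic carbon). All three measured compounds carry the 4-methoxyphenyl group, so no measurement tests this change directly. The measured steps all concern a different place in the molecule: a number 2 percentage points higher from compound 1 to compound 2 (within the scatter), no change at the digits printed from compound 1 to compound 3 (within the scatter) and a number 2 percentage points lower from compound 2 to compound 3 (within the scatter). Among the compounds with values here, each is within the scatter, and they show only that those changes elsewhere left the read-out in this assay unmoved. They give no direction for the new change, so no step beyond the scatter is expected, though the range must stay wide.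

The expected change is a number 2 percentage points lower from compound 3 to compound 4 (within the scatter), which is estimated to lie within the scatter. The estimate for compound 4 is 74%, with an expected range from 58% to 86%.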

Compound 4, percent growth inhibition at one concentration: 59%
Beside the measured number, compound 4's estimate is 15 percentage points above it; low and high end bracket the measured number.
By their numbers in this assay, from the lowest: compound 4; then compounds 1, 3 and 2 (each within the scatter of the next).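

In this assay, exchanging 4-methoxyphenyl for 4-fluorophenyl gave a number 17 percentage points lower from compound 3 to compound 4 (beyond the scatter), the only step among these compounds that lies beyond the scatter. Compounds 1, 2 and 3 all carry the 4-methoxyphenyl group and differ only elsewhere in the molecule, where thiophen-2-yl, (naphthalen-1-yl)methyl and 4-fluorobenzyl could not be told apart, so they gave no reading of this position; compound 4 shows that the read-out does respond to the group found here, and that fluoro does not stand in for methoxy without loss. The data on hand offer nothing that explains this step.

The compounds shown leave open whether the step belongs to the loss of methoxy or to the arrival of fluoro, and whether a hydroxy group, an ethoxy group, a dimethylamino group or a chlorine atom at the same place would stay level with compound 3 or fall with compound 4. They also leave open whether the same exchange would cost as much when the 4-fluorobenzyl group is replaced by thiophen-2-yl or (naphthalen-1-yl)methyl.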